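A Second Halogen for Compound 1: Expected Clearance

A few compounds are considered here, and "the series" means these few. Any claim that something is new, unique, unknown or untested is made for them only; others in the source may bear on it.

Compound 1 `CN1C[C@H](C(=O)Nc2ccc(F)cc2)[C@@H](c2ccc(/C=C/C(=O)Nc3ccccc3N)cc2)C1` was tested in an in vitro ADME assay on microsomes from liver (Homo sapiens) for pharmacokinetics, read by LC-MS, with a stated time of 10 min, tested at 1 uM (on this read-out higher numbers stand for fast clearance and lower numbers for slow clearance), where compound 1 gives 5 mL/min/kg. Among the three measured compounds this is the second highest number: compound 3 `CN1C[C@H](C(=O)Nc2ccc(Br)cc2)[C@@H](c2ccc(/C=C/C(=O)Nc3ccccc3N)cc2)C1` gives 3 mL/min/kg, while compound 2 `COc1ccc(NC(=O)[C@H]2CN(C)C[C@@H]2c2ccc(/C=C/C(=O)Nc3ccccc3N)cc2)cc1` gives 14 mL/min/kg. The step of a 1.7-fold lower number from compound 1 to compound 3 (0.22 log units; within the scatter) shows that exchanging one halogen for another on that aromatic carbon leaves the number essentially where it was, whereas a 2.8-fold higher number from compound 1 to compound 2 (0.45 log units; beyond the scatter) shows that a methoxy group raises it. Compound 4 `CN1C[C@H](C(=O)Nc2ccc(Cl)cc2F)[C@@H](c2ccc(/C=C/C(=O)Nc3ccccc3N)cc2)C1` carries 4-chloro-2-fluorophenyl in place of 4-fluorophenyl on an amide-type nitrogen. This resembles the halogen exchange of compound 3 more than the methoxy change of compound 2, because a 1.7-fold lower number from compound 1 to compound 3 (0.22 log units; within the scatter) stayed within the scatter. Compound 4 is therefore expected to show a 1.3-fold lower number from compound 1 to compound 4 (0.10 log units; within the scatter), nothing beyond the scatter, with an estimated value of 4 mL/min/kg and a range from 2 mL/min/kg to 9 mL/min/kg.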

Compound 4, clearance: 11 mL/min/kg
The estimate for compound 4 lay 2.8-fold (0.44 log units) below the measured number; the whole stated range lies below it.
By their numbers in this assay, from the lowest: compounds 3 and 1 (each within the scatter of the next); then compounds 4 and 2 (each within the scatter of the next).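

In this assay a change made only of halogens can move the number at this amide-type nitrogen beyond the scatter: 4-chloro-2-fluorophenyl gives a 2.2-fold higher number from compound 1 to compound 4 (0.34 log units; beyond the scatter) and a 3.7-fold higher number from compound 3 to compound 4 (0.56 log units; beyond the scatter) as well. The methoxy compound is no longer alone at the high end, given a 1.3-fold lower number from compound 2 to compound 4 (0.10 log units; within the scatter) here. No measurement available here accounts for this rise. The compounds shown leave open whether the chloro or the added fluoro carries the step, and how a phenyl bearing an amine or a carboxylic acid would read.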